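A few compounds are considered here, and "the series" means these few. Any claim that something is new, unique, unknown or untested is made for them only; others in the source may bear on it.

The set holds four compounds on two related cores. Compound 1 `Cc1nc2c(OCc3ccccc3)cccn2c1C` and compound 2 `Cc1nc2c(OCc3ccccc3)cccn2c1N` share one core; compound 3 `Cc1nc2c(OCc3ccccc3)nccn2c1N` and the still unmeasured compound 4 `Cc1nc2c(OCc3ccccc3)nccn2c1C` share the other. The difference between the two cores is not broken down here.

In a functional assay on the whole organism (stomach) with Canis familiaris (Canis lupus familiaris) as the target (on this read-out lower numbers stand for an effect already at smaller amounts and higher numbers for an effect only at larger amounts of compound), compound 1 gives 0.1 mg/kg, and compound 2 gives 0.1 mg/kg. Compound 3 gives 0.8 mg/kg in this assay, a value that stands above both other measured compounds by margins beyond the scatter.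

On the first core the change from compound 2 to compound 1 is methyl in place of amino on an aromatic carbon. The step this change made in this assay is no change at the digits printed from compound 2 to compound 1 (within the scatter).

The same change is applied on the second core: compound 4 differs from compound 3 by methyl in place of amino on an aromatic carbon. The change appears in two pairs among the compounds shown, and the two place descriptions agree word for word, so it is the same change in both pairs. For the measured compounds named here, the one measured precedent, the pair of compound 2 and compound 1, left the dose where it was, as no change at the digits printed from compound 2 to compound 1 (within the scatter) shows. On that precedent the step from compound 3 to compound 4 in this assay is expected to be no change at the digits printed from compound 3 to compound 4 (within the scatter). Compound 4 is therefore estimated at 0.8 mg/kg in this assay, with a range from 0.35 mg/kg to 1.8 mg/kg. This rests on compound 3, because 0.8 mg/kg is the starting point, and on the unchanged outcome no change at the digits printed from compound 2 to compound 1 (within the scatter) in the measured pair.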

Compound 4, dose for half-maximal effect in the Canis familiaris assay: 2 mg/kg
Compound 4: the middle estimate sits 2.5-fold (0.40 log units) below what was measured, outside the stated range (above it).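

In the Canis familiaris assay compound 4 gives 2 mg/kg, and the replacement of amino by methyl gives a 2.5-fold higher number from compound 3 to compound 4 (0.40 log units; beyond the scatter) on the second core, whereas on the first core it gave no change at the digits printed from compound 2 to compound 1 (within the scatter). Set side by side, the two steps cannot be told apart, so as far as these two pairs go, the change carries over from one core to the other without a demonstrable difference: the same change on two cores in the Canis familiaris assay, no change at the digits printed (within the scatter) from compound 2 to compound 1 and a 2.5-fold higher number (0.40 log units; beyond the scatter) from compound 3 to compound 4, 2.5-fold (0.40 log units) apart, within the scatter of two such steps This does not show that the two cores respond identically, since each core supplies only one pair and the step on the second core, taken alone, lies beyond the scatter, while in a physicochemical assay for acid dissociation, the same change gives a number 0.20 log units higher from compound 3 to compound 4 (within the scatter). In the physicochemical assay compound 3 gives 4.6 and compound 4 gives 4.8.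

The compounds shown leave open how other groups on this aromatic carbon, such as an ethyl group, a dimethylamino group or a carboxylic acid, would behave on either core. They also leave open whether a larger difference between the two cores would appear with such groups, or whether the agreement seen with methyl and amino would hold.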